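Amide Swap on an Anilino-Pyrimidine Antiproliferative Series

The source may hold more compounds than are shown below. What is called first, only, known or untested is meant among the compounds shown, and "the series" means these compounds.

Two measured compounds share a core built around a fluoropyrimidine with two anilino substituents. Compound 1 `CN(C)CC(=O)Nc1cccc(Nc2ncc(F)c(Nc3ccc(F)cc3)n2)c1` carries a ((dimethylamino)methyl)carbonyl)amino group on one aniline; in a functional assay on A549 cells (Homo sapiens) for antiproliferative activity, read by sulforhodamine B assay, with a stated time of 3 days (on this read-out lower numbers stand for stronger inhibition of growth and higher numbers for weaker inhibition of growth), compound 1 gives 1180 nM. Compound 2 `COc1ccc(N2CCN(C)CC2)cc1Nc1ncc(F)c(Nc2ccc(F)cc2)n1` instead bears a methoxy group and a methylpiperazine, and in this assay compound 2 gives 1130 nM. Compound 1 has the higher of the two numbers, but the two values lie within the scatter of each other, so they show no difference.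

Compound 3 `O=C(Nc1cccc(Nc2ncc(F)c(Nc3ccc(F)cc3)n2)c1)c1cnccn1` is the unmeasured analogue of compound 1 in which (pyrazin-2-yl in place of (dimethylamino)methyl on a carbonyl carbon). For the measured compounds named here, no step between measured compounds informs this change, so the expectation rests on the values alone. The step from compound 1 to compound 3 is expected to be small, likely within the scatter, as a 1.3-fold higher number from compound 1 to compound 3 (0.10 log units; within the scatter). For compound 3 the estimated value in this assay is 1500 nM, with a range from 400 nM to 6000 nM.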

Compound 3, concentration for 50% growth inhibition: 10300 nM
Compound 3: the middle estimate sits 6.9-fold (0.84 log units) below what was measured; measured number above the stated range.
By their numbers in this assay, from the lowest: compounds 2 and 1 (each within the scatter of the next); then compound 3.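

Putting pyrazin-2-yl in place of (dimethylamino)methyl on a carbonyl carbon gives an 8.7-fold higher number from compound 1 to compound 3 (0.94 log units; beyond the scatter) in this assay, so growth inhibition responds to the group carried at this position, something the earlier pair, which differs in more than one place, could not show. The change replaces a group with no ring by one six-membered aromatic ring with 2 hetero atoms, and this single step does not separate the arrival of that ring from the departure of the dimethylamino group. Nothing available explains the weaker inhibition of growth.

The compounds shown leave open how a phenyl ring or a morpholin-4-ylmethyl group on the same carbonyl carbon would behave. They also leave open whether a longer chain ending in a dimethylamino group would keep the value of compound 1 at 1180 nM.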